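A few compounds are considered here, and "the series" means these few. Any claim that something is new, unique, unknown or untested is made for them only; others in the source may bear on it.

Measured in an ADME assay on microsomes from liver (Homo sapiens) for metabolic stability, read by LC-MS, using NADPH, with stated times of 5 min and 30 min, tested at 1 uM; on this read-out lower numbers stand for slow clearance and higher numbers for fast clearance:
- compound 1 `O=C(Nc1ccccc1)c1cnc(NCc2c(F)ccc3c2CCO3)n2cnnc12`: 14 mL.min-1.g-1
- compound 2 `Cc1nccn1-c1cnc(NCc2c(F)ccc3c2CCO3)c2cn[nH]c(=O)c12`: 8 mL.min-1.g-1

Not yet measured: compound 3 `Fc1ccc2c(c1CNc1ncc(Oc3ccccc3)c3nncn13)CCO2`.

Compound 1 and compound 2 lie within the usual scatter of each other, so neither can be ranked above the other in this assay. Going by the values given here, they do not differ in a single place, so the pair gives no step for any one change.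

Compound 3 keeps the core of compound 1 and carries one change: phenoxy in place of phenylcarbamoyl on an aromatic carbon. This puts phenoxy in place of phenylcarbamoyl on an aromatic carbon, para to a large group. Among the compounds with values here, the series holds no measured example of this change, so its effect is unknown. Within the data shown here, the only anchors are compound 1 at 14 mL.min-1.g-1 and compound 2 at 8 mL.min-1.g-1. The expectation is therefore a small step at most, leaning slightly towards faster clearance and not clearly beyond the scatter. The estimated step is a 1.3-fold higher number from compound 1 to compound 3 (0.11 log units; within the scatter). For compound 3 the expected value is 18 mL.min-1.g-1, with an estimated range of 8 mL.min-1.g-1 to 40 mL.min-1.g-1.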

Compound 3, intrinsic clearance in microsomes: 18 mL.min-1.g-1
For compound 3 middle estimate and measured number coincide at the digits printed; measured number inside the range.
By their numbers in this assay, from the lowest: compounds 2, 1 and 3 (each within the scatter of the next, the first and the last beyond it).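

Phenoxy in place of phenylcarbamoyl on this aromatic carbon, para to a large group, gives a 1.3-fold higher number from compound 1 to compound 3 (0.11 log units; within the scatter) in this assay. Going by these compounds alone, this is the first single-place comparison, and it shows that this exchange does not separate compound 3 from compound 1 on intrinsic clearance, even though the hydrogen-bond donor of phenylcarbamoyl leaves and the six-membered aromatic ring of carbon only stays. No measurement on these compounds offers an explanation for this outcome.

Both groups compared at this position carry the same six-membered aromatic ring of carbon only, so the data cannot show whether that ring matters to the read-out or whether the position would respond to a group of another kind. As far as these compounds go, whether an amine, a carboxylic acid or a longer chain on this aromatic carbon would give a step beyond the scatter remains open, as does the effect of a fluorine or a methoxy group on the phenyl ring of phenoxy.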